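A few compounds are considered here, and "the series" means these few. Any claim that something is new, unique, unknown or untested is made for them only; others in the source may bear on it.

The series shares one core, seen in compound 1 `CCSc1nc(N)c2nc(O)n(Cc3ccccc3)c2n1`, compound 2 `Nc1ncnc2c1nc(O)n2Cc1ccc(Cl)cc1`, compound 3 `Nc1ncnc2c1nc(Cl)n2Cc1ccccc1` and the yet unmeasured compound 4 `Nc1ncnc2c1nc(I)n2Cc1ccccc1`. In a functional assay (spleen, spleen) for activation, with Mus musculus as the target (a lower number here means that less compound is needed, a higher number that more compound is needed for the effect), compound 1 gives 0.1 uM, while compound 2 gives 10 uM. Compound 3 stands apart from both: in this assay compound 3 is recorded only as a limit of > 10 uM, and not as a number. That limit is where one of the three values in this assay sits, as shown by the limit of > 10 uM in this assay, at which 1 of the 3 values shown sits; compound 3 is therefore the weakest of the three measured compounds on the numbers seen.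

The step to compound 4 is a single change, (iodo in place of chloro on an aromatic carbon), on the core of compound 3. Among the measured compounds shown here, no measured pair in this set shows the effect of such an exchange, so no step size is known for it. With nothing pointing the other way, the step from compound 3 to compound 4 is expected to be small or none beyond the scatter, as a number no higher from compound 3 to compound 4 (the limit leaves the size open) expresses, and compound 4 itself is estimated at 10 uM, most likely falling between 3 uM and 30 uM in this assay.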

Compound 4, minimum effective concentration: > 10 uM
Compound 4: a limit, no number; the forecaster's own chance of this, stated with the estimate: 50%; the middle value lies on the limit itself.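

Compound 3 and compound 4 are both recorded only as limits in this assay, so no step can be read between them: the limit of > 10 uM in this assay, at which 2 of the 4 values shown sit.
The compounds shown leave open whether iodo in place of chloro on an aromatic carbon changes the minimum effective concentration at all, and in which direction.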